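Aryl swap on the triazole hydroxamate series

This account rests on a few compounds, and the source may have more. Where it says the series, first, only, none or still open, it means among the compounds named here.

Measured compounds:
compound 1 `O=C(NO)c1ccc(NCc2nc(-c3ccc(Br)o3)nn2-c2ccccc2)cc1`, 55.8%
compound 2 `Cc1ccc(-n2nc(-c3ccccc3)nc2CNc2ccc(C(=O)NO)cc2)cc1`, 60.7%
compound 3 `Cc1ccccc1-c1nc(CNc2ccc(C(=O)NO)cc2)n(-c2ccccc2)n1`, 53.2%

In an assay on Sf9 cells for inhibition of protein deacetylase HDAC6 (Homo sapiens), read by fluorescence, with a stated time of 40 min, tested at 100 nM (on this read-out higher numbers stand for more inhibition at the one concentration tested (going by the name of the read-out) and lower numbers for less inhibition), compound 1 stands second highest of the three numbers. Its nearest neighbour is compound 3, the step of a number 2.6 percentage points lower from compound 1 to compound 3 (within the scatter) lying within the scatter, and compound 2 stands furthest, also within the scatter, so the three values cannot be ordered against one another.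

Compound 4 `Cc1cccc(-c2nc(CNc3ccc(C(=O)NO)cc3)n(-c3ccccc3)n2)c1` differs from compound 1 by 3-methylphenyl in place of 5-bromofuran-2-yl on an aromatic carbon. Going by the values given here, the one measured step that bears on this change is a number 2.6 percentage points lower from compound 1 to compound 3 (within the scatter), where 2-methylphenyl took the place of the same leaving group without a move beyond the scatter. Among the compounds with values here, no other measured pair isolates this group. Compound 4 is therefore expected to show no step beyond the scatter, the estimated step being a number 0.8 percentage points lower from compound 1 to compound 4 (within the scatter). For compound 4 the estimate is 55%, expected to fall between 40% and 70%.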

Compound 4, a percentage reported as inhibition, at one concentration (the size of the read-out at that concentration, not a potency): 64.1%
Compound 4: the middle estimate sits 9.1 percentage points below what was measured; measured number inside the range.
By their numbers in this assay, from the lowest: compounds 3, 1, 2 and 4 (each within the scatter of the next, the first and the last beyond it).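

In this assay, going by these compounds alone, the methyl position on the phenyl group at this ring carbon now matters: a number 10.9 percentage points higher from compound 3 to compound 4 (beyond the scatter) is the first step in the set beyond the scatter, though a modest one. Against 5-bromofuran-2-yl, 3-methylphenyl remains unresolved, with a number 8.3 percentage points higher from compound 1 to compound 4 (within the scatter) as the step. No measurement offered here accounts for the difference between the two methylphenyl groups.

Still open, going by these compounds, is whether this sensitivity extends to other substituents on that phenyl group. A carboxylic acid or an amine there would test this, and a single concentration leaves potency itself unsettled.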